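Methoxy on the anilino ring of a thiazolyl acetamide series

A few compounds are considered here, and "the series" means these few. Any claim that something is new, unique, unknown or untested is made for them only; others in the source may bear on it.

Measured compounds:
compound 1 `Cc1nc(SCC(=O)Nc2nc(-c3ccc(Cl)cc3)cs2)n(Nc2ccccc2)c1C` gives 4130 nM
compound 2 `Cc1ccc(Nn2c(SCC(=O)Nc3nc(-c4ccccc4)cs3)nc(C)c2C)cc1` gives 3980 nM

In a functional assay on COLO 205 cells (Homo sapiens) for antiproliferative activity, read by sulforhodamine B assay, with a stated time of 48 h (on this read-out higher numbers stand for weaker inhibition of growth and lower numbers for stronger inhibition of growth), compound 1 gives 4130 nM and compound 2 gives 3980 nM; the two numbers lie within the scatter of each other, so neither compound can be placed ahead of the other. Among the compounds with values here, compound 2 differs from compound 1 in two places, so no single step is available. Compound 3 `COc1ccc(Nn2c(SCC(=O)Nc3nc(-c4ccc(Cl)cc4)cs3)nc(C)c2C)cc1` carries methoxy in place of hydrogen on an aromatic carbon. Within the data shown here, no comparable step has been measured; the expected step of a 1.3-fold lower number from compound 1 to compound 3 (0.11 log units; within the scatter) is therefore small and not beyond the scatter. Compound 3 is expected to give 3200 nM, within 1000 nM to 10000 nM.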

Compound 3, concentration for 50% growth inhibition: 1940 nM
Compound 3: the middle estimate sits 1.6-fold (0.22 log units) above what was measured; low and high end bracket the measured number.
By their numbers in this assay, from the lowest: compound 3; then compounds 2 and 1 (each within the scatter of the next).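

In this assay, within the data shown here, the change from phenyl to 4-methoxyphenyl gives a 2.1-fold lower number from compound 1 to compound 3 (0.33 log units; beyond the scatter), the first step that can be read at a single place. The anilino ring therefore accepts a substituent para to a large group, and here growth inhibition is modestly stronger with it. The data give no reason for this step. On these data alone, it remains open whether a hydroxyl, an amine or an ethoxy group at this place would give a similar step. As far as these compounds go, it is also open whether methoxy would give the same step on the core of compound 2.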